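Series notes: a carboxy on the phenyl of compound 2

The source may report more compounds than this note shows. Statements on the series, on what has been measured and on what is new or still open speak of the compounds shown alone.

Measured compounds:
compound 1 `CCCCCCCCc1ccc(OCC(=O)Cn2nnc(C)n2)cc1` — < 5%
compound 2 `CCCCCCCCc1ccc(OCC(=O)Cn2nnc(-c3ccccc3)n2)cc1` — 33%
compound 3 `CCCCCCCCc1ccc(OCC(=O)Cn2nnc(C(=O)OC)n2)cc1` — < 5%

In an ADME assay on S9 fraction from liver (Rattus norvegicus) for metabolic stability, read by LC-MS, using NADPH, with a stated time of 30 min (on this read-out higher numbers stand for a more stable compound and lower numbers for a less stable compound), compound 1 gives < 5%, which is a limit of the assay and not a number. Compound 3 likewise gives < 5%, again a limit. For the measured compounds named here, compound 2 gives 33%, the only actual number among the three, the other two sitting at the limit of < 5% in this assay, at which 2 of the 3 values shown sit. The steps of a number at least 28 percentage points higher from compound 1 to compound 2 (beyond the scatter) and a number at least 28 percentage points lower from compound 2 to compound 3 (beyond the scatter) both concern the group on the aromatic carbon of the shared core; the step that the two limits leave unreadable from compound 1 to compound 3 cannot be sized. Going by the values given here, compound 4 `CCCCCCCCc1ccc(OCC(=O)Cn2nnc(-c3cccc(C(=O)O)c3)n2)cc1` differs from compound 2 by carboxy in place of hydrogen on an aromatic carbon, a change on the phenyl itself, which no measured step covers. With nothing directly bearing on it, a step of at most modest size in either direction is expected, a number 7 percentage points higher from compound 2 to compound 4 (within the scatter). Compound 4 is estimated at 40%, between 15% and 70%.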

Compound 4, percent of the compound remaining: < 5%
Compound 4 ended at the assay's limit (the forecaster's own chance of this, stated with the estimate: 10%); at least 35 percentage points between middle value and limit.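

On the phenyl itself, the place is not indifferent in this assay: carboxy in place of hydrogen, on an aromatic carbon meta to a large group, gives a number at least 28 percentage points lower from compound 2 to compound 4 (beyond the scatter). The earlier steps shown here only exchanged the whole group on the aromatic carbon of the shared core, so a group added to the phenyl can undo what the phenyl gave. The steps to compound 4 from compound 1 and compound 3 cannot be read, and the series now sits mostly at a limit: the limit of < 5% in this assay, at which 3 of the 4 values shown sit.

On these data alone, whether this holds for carboxy alone remains open, since a hydroxy, an amine or a primary amide at this place could read differently. Also open, as far as these compounds go, is whether carboxy elsewhere on the phenyl behaves the same.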